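Triazole substituent changes on a shared lactone core

The compounds below may be only part of what the source reports. "The series", "measured", "known", "first", "only" and "open" are said of these compounds alone.

Compound 1 `COc1ccccc1-c1cn(C[C@H](O)[C@H]2OC(=O)C(OCc3ccccc3)=C2OCc2ccccc2)nn1`: in a functional assay on HeLa cells (Homo sapiens) for antiproliferative activity, read by MTT assay, with a stated time of 72 h (a lower number here means a stronger inhibitor, a higher number a weaker inhibitor), compound 1 gives > 100000 nM, a limit of the assay and not a number.
Compound 2 `CCCCCCCCCCc1cn(C[C@H](O)[C@H]2OC(=O)C(OCc3ccccc3)=C2OCc2ccccc2)nn1`: compound 2 gives 22900 nM.
Compound 3 `O=C1O[C@H]([C@@H](O)Cn2cc(C3CC3)nn2)C(OCc2ccccc2)=C1OCc1ccccc1`: compound 3 gives 26500 nM.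

Among the two numbers shown, compound 3 stands highest; its nearest neighbour is compound 2, and the gap a 1.2-fold higher number from compound 2 to compound 3 (0.06 log units; within the scatter) lies within the scatter. Compound 1 sits at a limit (the limit of > 100000 nM in this assay, at which 1 of the 3 values shown sits), so the steps of an at least 4.3-fold lower number from compound 1 to compound 2 (0.64 log units; beyond the scatter) and an at least 3.7-fold lower number from compound 1 to compound 3 (0.57 log units; beyond the scatter) can only be given as lower bounds. Compound 4 `O=C1O[C@H]([C@@H](O)Cn2cc(CNS(=O)(=O)c3ccc(Cl)cc3)nn2)C(OCc2ccccc2)=C1OCc1ccccc1` arises from compound 3 by the change ((((4-chlorophenyl)sulfonyl)amino)methyl in place of cyclopropyl on an aromatic carbon). For the measured compounds named here, no measured step replaces a cyclopropyl with a group of this kind, so the measured steps bear on it only indirectly: the two aliphatic groups in compound 2 and compound 3 gave numbers within the scatter of each other, while the aryl-bearing compound 1 reached only a limit. The new group carries an aromatic ring, as compound 1 does, so compound 4 is expected to show a step of a 1.5-fold higher number from compound 3 to compound 4 (0.18 log units; within the scatter) in this assay toward a higher number. Compound 4 is therefore estimated at 40000 nM, within a range from 10000 nM to 150000 nM.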

Compound 4, half-maximal inhibitory concentration: 13600 nM
Compound 4: middle estimate off by 2.9-fold (0.47 log units), on the high side; the range from low to high includes it.
By their numbers in this assay, from the lowest: compounds 4, 2 and 3 (each within the scatter of the next). At a limit, above all of these: compound 1.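

In this assay, the change gives a 1.9-fold lower number from compound 3 to compound 4 (0.29 log units; within the scatter) and, against the decyl compound, a 1.7-fold lower number from compound 2 to compound 4 (0.23 log units; within the scatter), so this aromatic carbon of the five-membered ring takes the (((4-chlorophenyl)sulfonyl)amino)methyl group with a number that cannot be told apart from those of the two aliphatic groups. An aromatic ring in the substituent therefore does not by itself go with the result for compound 1, as the step of an at least 7.3-fold lower number from compound 1 to compound 4 (0.86 log units; beyond the scatter) shows, although that step is only a lower bound. Compound 1 stands at a limit and not at a number: the limit of > 100000 nM in this assay, at which 1 of the 4 values shown sits.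

The compounds shown leave open which part of the new group matters: the sulfonyl amino link, the chlorine or the phenyl ring. They also leave open whether an amine or a carboxylic acid on this carbon would move the number beyond the scatter.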